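The source may hold more compounds than are shown below. What is called first, only, known or untested is meant among the compounds shown, and "the series" means these compounds.

In an assay on microsomes from intestine for inhibition of acyl-CoA:cholesterol acyltransferase (Oryctolagus cuniculus) (a lower number here means a stronger inhibitor, a higher number a weaker inhibitor), three compounds have been measured so far. Compound 1 `CCCCCCCCCCC(CC)(CC)C(=O)Nc1c(OC)cc(OC)cc1OC` gives 97 nM, and compound 2 `CCCCCCCCCCCCC(CC)C(=O)Nc1c(OC)cc(OC)cc1OC` gives 52 nM. Compound 3 `CCCCCCCCCCC(C)(C)C(=O)Nc1ccc(C)cc1C` gives 680 nM, which is the highest of the three numbers: the gap to compound 1 and the larger gap to compound 2 both lie beyond the scatter, so compound 3 is the weakest inhibitor of the set on these numbers.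

Compound 4 `CCCCCCCCCCC(C)(C)C(=O)Nc1c(C)cccc1C` has not yet been measured in this assay. It is built from the same atoms as compound 3, joined differently: 2,6-dimethylphenyl in place of 2,4-dimethylphenyl on an amide-type nitrogen. Within the data shown here, no measured pair in the set differs only at this position, so there is no step on record to lean on. The two more potent compounds, compound 1 and compound 2, both carry a ring that is substituted on the two carbons flanking the amide-bearing carbon, which is the arrangement compound 4 adopts. On that basis compound 4 is expected to show a 3.1-fold lower number from compound 3 to compound 4 (0.49 log units; beyond the scatter), a move toward a lower number that is expected to lie beyond the scatter but not by a large margin. Compound 4 is therefore expected to reach about 220 nM, with a plausible range from 70 nM to 700 nM.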

Compound 4, half-maximal inhibitory concentration: 1300 nM
Compound 4: middle estimate off by 5.9-fold (0.77 log units), on the low side, and the stated range ends below it.
By their numbers in this assay, from the lowest: compounds 2 and 1 (each within the scatter of the next); then compounds 3 and 4 (each within the scatter of the next).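

Among these compounds, compound 3 and compound 4 form the first pair in the set that differs in one place only, giving a step on record for 2,6-dimethylphenyl in place of 2,4-dimethylphenyl on an amide-type nitrogen (a 1.9-fold higher number from compound 3 to compound 4 (0.28 log units; within the scatter)). Read in this assay the two dimethylphenyl groups cannot be told apart, so this change at this position, taken alone, does not shift the number beyond what repeated measurements would give. Nothing on record explains this result or says what the two groups do differently.

The compounds shown leave open how much of the distance from compound 3 and compound 4 to compound 1 and compound 2 belongs to the group on the nitrogen and how much to the chain on the carbonyl carbon, as neither of the latter two differs from either of the former in one place only. Also open, as far as these compounds go, is how the number would respond on this same nitrogen to a 2,4,6-trimethylphenyl group, or to a ring carrying an amine or a carboxylic acid.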